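Methyl on the Ring Oxygen: From Compound 1 to Compound 4

The compounds below may be only part of what the source reports. "The series", "measured", "known", "first", "only" and "open" are said of these compounds alone.

Compound 1 `Cc1cc(O)nc(NC(=S)NC(=O)c2c(-c3ccc(Cl)cc3Cl)noc2C)n1` was examined in a functional assay on the whole organism for inhibition, with Digitaria ciliaris as the target, with a stated time of 72 h, tested at 100 mg/L (a lower number here means less inhibition of growth, a higher number more inhibition of growth at the concentration tested), where compound 1 gives 49.3%, the lowest of the three numbers recorded. Compound 2 `CSc1cc(C)nc2n/c(=N/C(=O)c3c(-c4ccc(Cl)cc4Cl)noc3C)sn12` gives 70.6% in this assay, and compound 3 `COc1cc(Cl)nc2n/c(=N/C(=O)c3c(-c4ccc(Cl)cc4Cl)noc3C)sn12` gives 72.8%; each of these lies beyond the scatter above the number for compound 1.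

Compound 4 `COc1cc(C)nc(NC(=S)NC(=O)c2c(-c3ccc(Cl)cc3Cl)noc2C)n1` differs from compound 1 in a single place: methyl in place of hydrogen on an oxygen on an aromatic ring. For the measured compounds named here, no measured pair traces this exact change, so the size of the step cannot be read from a neighbour; a moderate rise in growth inhibition is expected, and a number 8.7 percentage points higher from compound 1 to compound 4 (within the scatter) is the estimated step. Compound 4 is accordingly expected to give 58% in this assay, with a range from 40% to 76%.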

Compound 4, percent growth inhibition at one concentration: 60.2%
For compound 4 the middle estimate is 2.2 percentage points below the measured one; the range from low to high includes it.
By their numbers in this assay, from the lowest: compound 1; then compound 4; then compounds 2 and 3 (each within the scatter of the next).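

For the compounds shown here, replacing hydroxy with methoxy on the 4-hydroxy-6-methylpyrimidin-2-yl group gives the first step that can be read at this place: in this assay it brings a number 10.9 percentage points higher from compound 1 to compound 4 (beyond the scatter) at the concentration tested. In this pair, the hydrogen on the oxygen is therefore not required for growth inhibition, and a methyl there is accompanied by a modest rise. Nothing available accounts for this rise.

Going by these compounds, whether an ethyl or a longer chain on this oxygen would continue the rise remains open. So does how an amine in place of the hydroxy would compare.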